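The source may report more compounds than this note shows. Statements on the series, on what has been measured and on what is new or still open speak of the compounds shown alone.

Measured compounds and their values:
Compound 1, `CCOC(=O)c1cnc(N2CCN(Cc3ccccc3C(F)(F)F)CC2)nc1Oc1c(C)cc(-c2ccc(C#N)cc2)cc1C`, in an ADME assay on MT4 cells (Homo sapiens) for cytotoxicity, read by MTT assay, with a stated time of 4 days; on this read-out lower numbers stand for higher toxicity in this test and higher numbers for lower toxicity in this test: > 125000 nM.
Compound 2, `CCOC(=O)c1cnc(N2CCN(Cc3cccc(F)c3)CC2)nc1Oc1c(C)cc(-c2ccc(C#N)cc2)cc1C`: > 125000 nM.
Compound 3, `CCOC(=O)c1cnc(N2CCN(Cc3cccc(C(=O)OC)c3)CC2)nc1Oc1c(C)cc(-c2ccc(C#N)cc2)cc1C`: > 125000 nM.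

Each of these three values is a limit of the assay, not a number: the test ran out before any half-maximal effect was reached. Compound 1 therefore stands only at a limit, and the same is true of the two companions, as the limit of > 125000 nM in this assay, at which 3 of the 3 values shown sit, shows.

The move to the unmeasured compound 4, `CCOC(=O)c1cnc(N2CCN(Cc3ccccc3C(=O)OC)CC2)nc1Oc1c(C)cc(-c2ccc(C#N)cc2)cc1C`, is methoxycarbonyl in place of trifluoromethyl on an aromatic carbon. It changes the group carried by the benzyl arm, 2-(trifluoromethyl)benzyl to 2-(methoxycarbonyl)benzyl, and leaves the shared core of compound 1 untouched.

Within the data shown here, three measured steps bear on this change. a step that the two limits leave unreadable from compound 1 to compound 2, a step that the two limits leave unreadable from compound 1 to compound 3 and a step that the two limits leave unreadable from compound 2 to compound 3 all compare two limits, so none of them gives a readable size or direction. Compound 3 already carries a methoxycarbonyl on the benzyl arm, only at a different position, and it too sits at the limit.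

With nothing readable in any step, no step beyond the scatter is expected in this assay. The estimate for compound 4 is 200000 nM, between 100000 nM and 500000 nM, and the expected step is a step that the limit leaves unreadable from compound 1 to compound 4, most likely reported again as a limit.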

Compound 4, half-maximal cytotoxic concentration: > 125000 nM
Compound 4 ended at the assay's limit (the forecaster's own chance of this, stated with the estimate: 90%); the middle value lies beyond the limit too.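

In this assay compound 4 gives > 125000 nM as a limit, not a number. Its steps from compound 1, compound 2 and compound 3 all compare two limits and cannot be read: the limit of > 125000 nM in this assay, at which 4 of the 4 values shown sit.

The compounds shown leave open at what concentration any of them reaches a half-maximal cytotoxic effect, and whether the benzyl group changes that concentration.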